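A few compounds are considered here, and "the series" means these few. Any claim that something is new, unique, unknown or untested is made for them only; others in the source may bear on it.

Measured compounds:
compound 1 `O=c1cc(Cn2cc(CCCCO)nn2)c2ccc(O)cc2o1`: > 100000 nM
compound 2 `O=c1cc(Cn2cc(CNS(=O)(=O)c3ccc(Cl)cc3)nn2)c2ccc(O)cc2o1`: 58500 nM

In a functional assay on HeLa cells (Homo sapiens) for inhibition, read by MTT assay, with a stated time of 72 h (a higher number here means a weaker inhibitor, a lower number a stronger inhibitor), compound 1 gives > 100000 nM, which is a limit of the assay rather than a number. Compound 2 gives 58500 nM in this assay, the only number shown there. The other value stands at a limit (the limit of > 100000 nM in this assay, at which 1 of the 2 values shown sits). Compound 3 `O=c1cc(Cn2cc(CNS(=O)(=O)c3ccc(F)cc3Cl)nn2)c2ccc(O)cc2o1` differs from compound 2 by 2-chloro-4-fluorophenyl in place of 4-chlorophenyl on a sulfonyl sulfur. No step between measured compounds is shown, so the expectation rests on this change alone: a step within the usual scatter, in no set direction, is expected, a 1.2-fold lower number from compound 2 to compound 3 (0.07 log units; within the scatter). Compound 3 is therefore estimated at 50000 nM, between 15000 nM and 150000 nM.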

Compound 3, half-maximal inhibitory concentration: 74900 nM
Compound 3: middle estimate off by 1.5-fold (0.18 log units), on the low side; low and high end bracket the measured number.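

In this assay, within the data shown here, 2-chloro-4-fluorophenyl in place of 4-chlorophenyl on a sulfonyl sulfur gives a 1.3-fold higher number from compound 2 to compound 3 (0.11 log units; within the scatter) and so provides the first readable step at this position. The two aryl groups cannot be told apart in this assay, so this change to the ring does not move the reading beyond the scatter. Nothing given here bears on the size of this step.

From the compounds shown here alone, it remains open whether an amine or a carboxylic acid on the phenyl ring would move the number beyond the scatter. The same is open for a methyl group on the sulfonyl sulfur in place of the ring.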